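Anilino for phenyl on a shared indazole-like kinase inhibitor core

The source may hold more compounds than are shown below. What is called first, only, known or untested is meant among the compounds shown, and "the series" means these compounds.

Measured so far:
compound 1, `Cn1cc(-c2n[nH]c3ccc(NC4CCNC4)cc23)cn1`, in an assay on isolated protein for inhibition of tyrosine-protein kinase receptor UFO (Homo sapiens), with a stated time of 1.5 h; a higher number here means a weaker inhibitor, a lower number a stronger inhibitor: 132000 nM
compound 2, `Cn1cc(-c2n[nH]c3cc(-c4ccccc4)ccc23)cn1`, in this assay: 12300 nM

Compound 2 has the lowest number of the two measured compounds; compound 1 gives a higher number, and that gap lies beyond the usual scatter. Compound 3, `Cn1cc(-c2n[nH]c3cc(Nc4ccccc4)ccc23)cn1`, has not yet been measured. It differs from compound 2 in one place: anilino in place of phenyl on an aromatic carbon. Within the data shown here, no step between two measured compounds that differ in only one place is available, so the effect of this particular change cannot be read from the numbers already in hand. A small step is expected, likely within the scatter or at most a modest decrease in the number: a 1.5-fold lower number from compound 2 to compound 3 (0.19 log units; within the scatter). For compound 3 the estimated value is 8000 nM, with a range from 2000 nM to 40000 nM.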

Compound 3, half-maximal inhibitory concentration: 219000 nM
Beside the measured number, compound 3's estimate is 27-fold (1.44 log units) below it, outside the stated range (above it).
By their numbers in this assay, from the lowest: compound 2; then compounds 1 and 3 (each within the scatter of the next).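

In this assay, among these compounds, putting anilino in place of phenyl on this aromatic carbon gives an 18-fold higher number from compound 2 to compound 3 (1.25 log units; beyond the scatter), the first step here that isolates a change in one place. The aromatic ring of carbon stays, and the change adds one nitrogen atom, bringing one hydrogen-bond donor and one hydrogen-bond acceptor, so the number at this position is highly sensitive to a small structural edit. Nothing available explains why this edit gives a weaker inhibitor.

As far as these compounds go, it remains open whether any atom linking the ring to the core has a similar effect, which a benzyl group, linked through carbon, or a phenoxy group, linked through oxygen, would test. Also open, from the compounds shown here alone, is whether an amine on the phenyl ring of compound 2 would lower or raise the number.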